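A few compounds are considered here, and "the series" means these few. Any claim that something is new, unique, unknown or untested is made for them only; others in the source may bear on it.

Measured so far in a functional assay on A549 cells (Homo sapiens) for cytotoxicity, read by MTT assay, with a stated time of 48 h; a lower number here means a stronger inhibitor, a higher number a weaker inhibitor:
compound 1 `COc1ccc(OC)c(C2=NOC(COc3ccc(-c4nnnn4-c4cc(OC)c(OC)c(OC)c4)cc3N)C2)c1`: 1930 nM
compound 2 `COc1cc(-n2nnnc2-c2ccc(OCC3CC(c4ccc(C(F)(F)F)cc4)=NO3)c(N)c2)cc(OC)c1OC`: 1220 nM

For the measured compounds named here, compound 2 and compound 1 sit at one level; the only step, a 1.6-fold lower number from compound 1 to compound 2 (0.20 log units; within the scatter), is within the scatter, so compound 2 is not separated from compound 1 on these numbers.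

Compound 3 `COc1ccc(C2=NOC(COc3ccc(-c4nnnn4-c4cc(OC)c(OC)c(OC)c4)cc3N)C2)cc1O` differs from compound 2 in a single place: 3-hydroxy-4-methoxyphenyl in place of 4-(trifluoromethyl)phenyl on a carbon with a double bond to nitrogen. Going by the values given here, the one step that bears on this change is a 1.6-fold lower number from compound 1 to compound 2 (0.20 log units; within the scatter), which swapped the aryl on the same carbon with a double bond to nitrogen and did not move the number beyond the scatter. From the compounds shown here alone, two points give no slope to extend, so no step beyond the scatter is expected in this assay for compound 3; the 3-hydroxy-4-methoxyphenyl is untested here, which widens the range.

Compound 3 is therefore estimated at 1500 nM, with a range of 600 nM to 4000 nM, an expected step of a 1.2-fold higher number from compound 2 to compound 3 (0.09 log units; within the scatter).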

Compound 3, half-maximal inhibitory concentration: 2130 nM
Compound 3: the middle estimate sits 1.4-fold (0.15 log units) below what was measured; low and high end bracket the measured number.
By their numbers in this assay, from the lowest: compounds 2, 1 and 3 (each within the scatter of the next).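

In this assay the change from 4-(trifluoromethyl)phenyl to 3-hydroxy-4-methoxyphenyl on the carbon with a double bond to nitrogen gives a 1.7-fold higher number from compound 2 to compound 3 (0.24 log units; within the scatter) and the change from 2,5-dimethoxyphenyl to the same group gives a 1.1-fold higher number from compound 1 to compound 3 (0.04 log units; within the scatter) so a hydroxy-bearing aryl group now joins the other two at one level. At this position, three aryl groups with different substituents, fluorine-bearing in compound 2 and oxygen-bearing in compound 1 and compound 3, are not separated from one another. No measurement on hand offers an account of this flat reading.

From the compounds shown here alone, whether an amine or a carboxylic acid on this aryl ring, or a longer alkyl chain in place of it, would move the number beyond the scatter stays open. Going by these compounds, all three compounds share the same core, so the effect of changes elsewhere on it also stays open.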